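The compounds below may be only part of what the source reports. "The series", "measured", "known", "first", "only" and "open" are said of these compounds alone.

The series consists of three urea compounds that share one core and differ only in the chlorine pattern on the aryl ring and in the configuration at the saturated chain carbon. Compound 1, `C[C@H](NC(=O)Nc1cccc(Cl)c1)c1ccccc1`, carries a single chlorine, and in an ADME assay on the whole organism with Oryza sativa as the target, tested at 10 uM (on this read-out higher numbers stand for a weaker effect at the one concentration tested and lower numbers for a stronger effect), compound 1 gives 103%. Compound 2, `C[C@@H](NC(=O)Nc1ccc(Cl)c(Cl)c1)c1ccccc1`, carries two chlorines; in this assay compound 2 gives 93%. Compound 2 and compound 1 lie within the usual scatter of each other, so the two numbers tell no difference between them on this read-out; both stand near the point where the effect at the tested concentration is weak.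

Compound 3, `C[C@H](NC(=O)Nc1ccc(Cl)c(Cl)c1)c1ccccc1`, is the mirror partner of compound 2: the two compounds have the same atoms and bonds and differ only in configuration as drawn: 1 of 1 stereo elements differ; a stereocentre at a saturated chain carbon is drawn R in compound 2 and S in compound 3. Among the measured compounds shown here, no step between two measured compounds covers a change of configuration alone, so the size of the step from compound 2 to compound 3 can only be guessed. The author expects no step beyond the scatter, in either direction, for a number 4 percentage points higher from compound 2 to compound 3 (within the scatter). For compound 3 in this assay the estimate is 97%, with a range from 82% to 110%.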

Compound 3, a percentage reported as activity, at one concentration (the size of the read-out at that concentration, not a potency): 99%
Beside the measured number, compound 3's estimate is 2 percentage points below it, and the stated range covers the measured number.
By their numbers in this assay, from the lowest: compounds 2, 3 and 1 (each within the scatter of the next).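

Changing the stereocentre at a saturated chain carbon from R to S gives a number 6 percentage points higher from compound 2 to compound 3 (within the scatter) in this assay, so configuration at this position has no effect that this read-out can resolve in the dichloro pair. The chlorine change can now also be read on its own, which the first two compounds did not allow, as they differed in both chlorine pattern and configuration: chloro in place of hydrogen on an aromatic carbon gives a number 4 percentage points lower from compound 1 to compound 3 (within the scatter), again without a difference that can be told from the scatter. The first of these steps can be read as a matter of configuration and nothing else because of one fact: the fact that compounds 2 and 3 differ only in the configuration as drawn.

On these data alone, whether a carboxylic acid or an amine on the aryl ring, or a longer chain at the saturated chain carbon, would move the number in this assay beyond the scatter remains open. Also open is whether the two configurations would separate in a compound with a clearly stronger effect at the tested concentration, since the compounds shown give no such case.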